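A few compounds are considered here, and "the series" means these few. Any claim that something is new, unique, unknown or untested is made for them only; others in the source may bear on it.

Measured so far:

Compound 1, `Oc1nc(NCC2CCCCC2)nc2ccc(Cl)cc12`, gives 2200 nM.
Compound 2, `C[C@H](Nc1nc(O)c2cc(Cl)ccc2n1)C1CCCCC1`, gives 2100 nM.
Compound 3, `CC(C)Nc1nc(O)c2cc(I)ccc2n1`, gives 12100 nM.

All three numbers come from a functional assay (aorta) for inhibition, with Rattus norvegicus as the target; a higher number here means a weaker inhibitor, a lower number a stronger inhibitor. Compound 2 differs from compound 1 by methyl in place of hydrogen on a saturated chain carbon bound to a nitrogen on an aromatic ring and a saturated ring carbon, and the step of a 1.0-fold lower number from compound 1 to compound 2 (0.02 log units; within the scatter) shows that this addition left the reading essentially where it was. Compound 3 stands apart from compound 1 in more than one place, so the difference between the two cores is not broken down here; what the values show is that compound 3 gives a higher number than either compound 1 or compound 2.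

Compound 4, `CCC(C)Nc1nc(O)c2cc(I)ccc2n1`, is not yet measured. It differs from compound 3 by methyl in place of hydrogen on a saturated chain carbon, two bonds along the chain from a nitrogen on an aromatic ring. Among the compounds with values here, this is the same kind of change as the one from compound 1 to compound 2, but not the same: there the added methyl sits on a carbon bound to a nitrogen on an aromatic ring and a saturated ring carbon, here two bonds along the chain from that nitrogen. Because a 1.0-fold lower number from compound 1 to compound 2 (0.02 log units; within the scatter) lay within the scatter, the step of a 1.1-fold lower number from compound 3 to compound 4 (0.04 log units; within the scatter) is expected to be small as well. Compound 4 is therefore estimated at 11000 nM, with a likely range from 5000 nM to 25000 nM.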

Compound 4, half-maximal inhibitory concentration: 8900 nM
Compound 4: the middle estimate sits 1.2-fold (0.09 log units) above what was measured, and the stated range covers the measured number.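

In this assay, adding the methyl gives a 1.4-fold lower number from compound 3 to compound 4 (0.13 log units; within the scatter), so on this core too the change leaves the reading about where it was. Set beside the earlier step, the change carries over from one core to the other with no difference that can be told apart from ordinary repeat variation: the same change on two cores in this assay, a 1.0-fold lower number (0.02 log units; within the scatter) from compound 1 to compound 2 and a 1.4-fold lower number (0.13 log units; within the scatter) from compound 3 to compound 4, 1.3-fold (0.11 log units) apart, within the scatter of two such steps

Within the data shown here, this does not show that the methyl is without effect on every core, since it rests on only two pairs of compounds in a single assay, and the methyl sits at a different place in each pair, here on a saturated chain carbon, two bonds along the chain from a nitrogen on an aromatic ring.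

The compounds shown leave open whether a group other than methyl at this place, such as an amine, a carboxylic acid or a longer chain, would move the reading. They also leave open whether the methyl would stay just as silent on a third core.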